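Second thiophene on the shared core: weak series, weak precedent

This account rests on a few compounds, and the source may have more. Where it says the series, first, only, none or still open, it means among the compounds named here.

Compound 1 `c1coc(-c2ccnc(-c3cccs3)c2)c1` is the reference point here. In a functional assay on HCT-15 cells (Homo sapiens) for antiproliferative activity (a higher number here means that more compound is needed for the effect, a lower number that less compound is needed), compound 1 gives 118000 nM. The only measured neighbour is compound 2 `c1coc(-c2ccnc(-c3ccco3)c2)c1`, which in this assay gives 118000 nM, so compound 1 stands level with compound 2 at the digits shown. For the measured compounds named here, the one measured step, no change at the digits printed from compound 1 to compound 2 (within the scatter), exchanges one five-membered heteroaryl group for another on the shared core and leaves the read-out unmoved within the scatter.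

Compound 3 `c1coc(-c2cc(-c3cccs3)nc(-c3cccs3)c2)c1` is not yet measured. It differs from compound 1 by thiophen-2-yl in place of hydrogen on an aromatic carbon. Going by the values given here, no measured step adds a group to a hydrogen on this core; the step from compound 1 to compound 2 concerns a swap of ring heteroatom only and so bears on the present change only in showing that the shared core tolerates either five-membered ring without any shift in this assay. Among the compounds with values here, with no precedent for adding a second thiophen-2-yl, the expected step is a 1.3-fold lower number from compound 1 to compound 3 (0.12 log units; within the scatter), that is, no change beyond the scatter in either direction. For compound 3 the estimate in this assay is therefore 90000 nM, with a range from 25000 nM to 250000 nM.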

Compound 3, half-maximal effective concentration: 118000 nM
The estimate for compound 3 lay 1.3-fold (0.12 log units) below the measured number; the measured number falls inside the stated range.
By their numbers in this assay, from the lowest: compounds 1, 2 and 3 (each within the scatter of the next).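

Thiophen-2-yl in place of hydrogen on the aromatic carbon next to the ring nitrogen gives, in this assay, no change at the digits printed from compound 1 to compound 3 (within the scatter), and this is the first step on the shared core that adds a group rather than exchanging one. The earlier step only replaced one five-membered aromatic ring with another, whereas this one shows that a position holding hydrogen in compound 1 can take a whole additional aromatic ring without the read-out leaving the scatter. Nothing measured in this set explains the unmoved number.

For the compounds shown here, the single added group leaves open whether the level read-out holds for this position generally or only for thiophen-2-yl. An amine, a carboxylic acid or a longer alkyl chain in place of the same hydrogen, each read against compound 1, would show whether any substituent here can move the number in this assay beyond the scatter.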